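Isopropyl on an aromatic nitrogen of compound 1

The source may report more compounds than this note shows. Statements on the series, on what has been measured and on what is new or still open speak of the compounds shown alone.

In a functional assay on BT-474 cells (Homo sapiens) for inhibition, read by MTT assay, with a stated time of 5 days (on this read-out higher numbers stand for weaker inhibition and lower numbers for stronger inhibition), compound 1 (`Cc1cc(Nc2nc(NCc3ccc(F)cc3F)nc3[nH]ncc23)n[nH]1`) gives 3220 nM as the lowest of three numbers, against compound 3 (`COc1ccc(CNc2nc(Nc3cc(C)[nH]n3)c3cn[nH]c3n2)cc1`) with 8230 nM and compound 2 (`Cc1cc(Nc2nc(NCc3ccc(C#N)cc3)nc3[nH]ncc23)n[nH]1`) with 12100 nM in the same test. Compound 4 (`Cc1cc(Nc2nc(NCc3ccc(F)cc3F)nc3c2cnn3C(C)C)n[nH]1`) carries isopropyl in place of hydrogen on an aromatic nitrogen, which adds isopropyl in place of hydrogen on an aromatic nitrogen to the structure. Among the measured compounds shown here, two measured steps bear only loosely on this: one is a 3.8-fold higher number from compound 1 to compound 2 (0.57 log units; beyond the scatter) and the other is a 2.6-fold higher number from compound 1 to compound 3 (0.41 log units; beyond the scatter) on replacing the 2,4-difluorophenyl group, and neither touches this nitrogen. With no measured guide to direction, no step beyond the scatter is expected in this assay and the estimated step is a 1.3-fold lower number from compound 1 to compound 4 (0.11 log units; within the scatter) with wide uncertainty. The estimate for compound 4 is 2500 nM as the expected middle, with 500 nM to 12000 nM as its range.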

Compound 4, half-maximal inhibitory concentration: 17300 nM
The estimate for compound 4 lay 6.9-fold (0.84 log units) below the measured number; measured number above the stated range.
By their numbers in this assay, from the lowest: compound 1; then compounds 3, 2 and 4 (each within the scatter of the next, the first and the last beyond it).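

Among the compounds shown here, the earlier steps changed only the aromatic group on the side chain, leaving hydrogen on this aromatic nitrogen, so this is the first reading at this position. Isopropyl in place of that hydrogen brings a 5.4-fold higher number from compound 1 to compound 4 (0.73 log units; beyond the scatter) in this assay and so weaker inhibition, showing that this position does not accept isopropyl without loss.

Going by these compounds, whether methyl, a smaller group, or a longer chain ending in an amine would fare differently on this nitrogen stays open. Nothing shown explains why isopropyl weakens inhibition here.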